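Aryl amide variation on the nitrobenzofurazan hexyl ester series

The source may report more compounds than this note shows. Statements on the series, on what has been measured and on what is new or still open speak of the compounds shown alone.

Three measured compounds share one core and differ only in the aryl group on the amide nitrogen: compound 1 `COc1ccccc1NC(=O)CCC(=O)OCCCCCCSc1ccc([N+](=O)[O-])c2nonc12`, compound 2 `O=C(CCC(=O)OCCCCCCSc1ccc([N+](=O)[O-])c2nonc12)Nc1cccc(Cl)c1` and compound 3 `O=C(CCC(=O)OCCCCCCSc1ccc([N+](=O)[O-])c2nonc12)Nc1ccc(F)cc1`. In a functional assay on 143B cells (Homo sapiens) for inhibition, read by MTT assay, with a stated time of 72 h (on this read-out higher numbers stand for weaker inhibition and lower numbers for stronger inhibition), compound 1 gives 2120 nM, compound 2 gives 2890 nM and compound 3 gives 2500 nM. Compound 2 carries the highest of the three numbers, yet every step to it stays inside the scatter: a 1.4-fold higher number from compound 1 to compound 2 (0.13 log units; within the scatter) and a 1.2-fold lower number from compound 2 to compound 3 (0.06 log units; within the scatter), while the remaining pair gives a 1.2-fold higher number from compound 1 to compound 3 (0.07 log units; within the scatter).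

Compound 4 `COc1ccc(NC(=O)CCC(=O)OCCCCCCSc2ccc([N+](=O)[O-])c3nonc23)cc1OC` is not yet measured. Relative to compound 2 the change is 3,4-dimethoxyphenyl in place of 3-chlorophenyl on an amide-type nitrogen. Within the data shown here, the steps that bear on it are the aryl swaps already seen: a methoxy-bearing phenyl in compound 1 against the 3-chlorophenyl of compound 2, and the 3-chlorophenyl against the 4-fluorophenyl of compound 3, none of which moved this assay beyond the scatter. Among the measured compounds shown here, a second methoxy on the ring has no measured precedent in this set.

On that basis compound 4 is expected to stay near compound 2 in this assay, with the expected step of a 1.2-fold lower number from compound 2 to compound 4 (0.08 log units; within the scatter) not beyond the scatter. The estimate for compound 4 is 2400 nM, with a range from 1200 nM to 4800 nM.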

Compound 4, half-maximal inhibitory concentration: 2770 nM
For compound 4 the middle estimate is 1.2-fold (0.06 log units) below the measured one; the measured number falls inside the stated range.
By their numbers in this assay, from the lowest: compounds 1, 3, 4 and 2 (each within the scatter of the next).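

In this assay, the amide-type nitrogen accepts 3,4-dimethoxyphenyl in place of 3-chlorophenyl, going from 7 to 10 heavy atoms and from 0 to 2 hydrogen-bond acceptors, with only a 1.0-fold lower number from compound 2 to compound 4 (0.02 log units; within the scatter). Among these compounds, the comparisons with the other two aryl groups read the same, with a 1.1-fold higher number from compound 3 to compound 4 (0.04 log units; within the scatter) and a 1.3-fold higher number from compound 1 to compound 4 (0.12 log units; within the scatter), so a ring carrying two methoxy groups joins the three singly substituted rings, and all four aryl amides now lie within the scatter of one another, with no compound in the set going against this. Nothing at hand speaks to the reason for this flat read-out.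

Still open, from the compounds shown here alone, is whether this position stays as flat with a group of another kind on the amide-type nitrogen, such as a phenyl ring bearing a carboxylic acid or a dimethylamino group, or a cyclohexyl group in place of the aromatic ring. Equally open, going by these compounds, is whether a shorter or longer chain in place of the hexyl linker would move the number in this assay beyond the scatter, which the aryl swaps have not done.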